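The source may hold more compounds than are shown below. What is called first, only, known or untested is meant among the compounds shown, and "the series" means these compounds.

Three compounds of the shared core have numbers in an assay on cell membranes with adenosine receptor A1 (Rattus norvegicus) as the target; on this read-out lower numbers stand for stronger inhibition and higher numbers for weaker inhibition. Compound 1 `C=CCn1c(=O)c2c(ncn2C)n(C)c1=O` gives 47000 nM. Compound 2 `CC(C)Cn1c(=O)n(C)c(=O)c2c1ncn2C` gives 19000 nM. Compound 3 `C#CCn1cnc2c1c(=O)n(C)c(=O)n2C` gives 12000 nM, the lowest of the three numbers; its gap to compound 2 lies within the scatter, while its gap to compound 1 lies beyond it. For the measured compounds named here, no pair of measured compounds differs in a single place, so no step of known size is at hand for the chain carbon bound to the aromatic nitrogen. Compound 4 `CC(=O)OCCn1cnc2c1c(=O)n(C)c(=O)n2C` differs from compound 3 by acetoxymethyl in place of ethynyl on a saturated chain carbon bound to an aromatic nitrogen. All three measured compounds, whatever group sits on that chain carbon, give weak inhibition, which speaks for the unmeasured compound staying in the same region. The step from compound 3 to compound 4 is expected to be a 2.1-fold higher number from compound 3 to compound 4 (0.32 log units; beyond the scatter), toward a higher number, with little confidence that it clears the scatter. Compound 4 is estimated at 25000 nM, within the range 8000 nM to 80000 nM.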

Compound 4, inhibition constant: 40000 nM
Estimate against measurement, compound 4: 1.6-fold (0.20 log units) below; low and high end bracket the measured number.
By their numbers in this assay, from the lowest: compounds 3 and 2 (each within the scatter of the next); then compounds 4 and 1 (each within the scatter of the next).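

In this assay, the series now has its first single-place step at the saturated chain carbon bound to an aromatic nitrogen: propargyl to 2-acetoxyethyl gives a 3.3-fold higher number from compound 3 to compound 4 (0.52 log units; beyond the scatter). This position therefore responds to the group it carries, and here the larger acetoxymethyl, with its two hydrogen-bond acceptors against none for ethynyl, goes with a higher number, although the size of the step is modest. No measurement at hand gives a reason for this step.

This single step does not separate the part played by the ester from that of the lost triple bond or the added chain length. On these data alone, a 2-hydroxyethyl group, a 2-aminoethyl group or a carboxylic acid on the same chain would test these, and it remains open whether any group here gives a clearly lower number than ethynyl.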